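The compounds below may be only part of what the source reports. "The series", "measured", "known", "first", "only" and "open" are said of these compounds alone.

Values in a functional assay on Bel7402/5-FU cells (Homo sapiens) for antiproliferative activity, read by MTT assay, with a stated time of 72 h; a higher number here means a weaker inhibitor, a lower number a stronger inhibitor:
- compound 1 `C=C1C(=O)O[C@H]2[C@H]1CC/C(COC(=O)Cn1cc(F)c(=O)n(Cc3ccc(C(F)(F)F)cc3)c1=O)=C\CC[C@@]1(C)O[C@@H]21`: 2250 nM
- compound 2 `C=C1C(=O)O[C@H]2[C@H]1CC/C(COC(=O)Cn1cc(F)c(=O)n(Cc3cccc(F)c3)c1=O)=C\CC[C@@]1(C)O[C@@H]21`: 3700 nM

Going by the values given here, compound 2 stands within the scatter of compound 1, the only other measured compound. Compound 3 `C=C1C(=O)O[C@H]2[C@H]1CC/C(COC(=O)Cn1cc(F)c(=O)n(Cc3c(F)cccc3F)c1=O)=C\CC[C@@]1(C)O[C@@H]21` carries 2,6-difluorophenyl in place of 3-fluorophenyl on a saturated chain carbon bound to an aromatic nitrogen. Among the compounds with values here, the one measured exchange at this place is a 1.6-fold higher number from compound 1 to compound 2 (0.22 log units; within the scatter). Within the data shown here, with only that step to go on, no step beyond the scatter is expected in this assay, and no direction can be expected. For compound 3 the estimated value is 3000 nM, with an expected range of 1200 nM to 7500 nM. The estimate means a 1.2-fold lower number from compound 2 to compound 3 (0.09 log units; within the scatter).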

Compound 3, half-maximal inhibitory concentration: 4980 nM
Compound 3: middle estimate off by 1.7-fold (0.22 log units), on the low side; low and high end bracket the measured number.
By their numbers in this assay, from the lowest: compounds 1, 2 and 3 (each within the scatter of the next, the first and the last beyond it).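

In this assay, going by these compounds alone, 2,6-difluorophenyl in place of 3-fluorophenyl on a saturated chain carbon bound to an aromatic nitrogen gives a 1.3-fold higher number from compound 2 to compound 3 (0.13 log units; within the scatter) and does not separate this pair. 2,6-Difluorophenyl in place of 4-(trifluoromethyl)phenyl gives a 2.2-fold higher number from compound 1 to compound 3 (0.35 log units; beyond the scatter) and is the first step at this place to pass the scatter, though only modestly. Nothing available accounts for either step.

Open, on these data alone, is how unsubstituted phenyl, a pyridine ring or an amine would read at this place in this assay and whether any would give a larger step.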